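Swapping one ring group on the core of compound 1

A few compounds are considered here, and "the series" means these few. Any claim that something is new, unique, unknown or untested is made for them only; others in the source may bear on it.

- compound 1 `O=c1ccn([C@@H]2O[C@H](CO)C(O)[C@@H]2OC2Sc3ccccc3S2)c(=O)[nH]1` gives 67300 nM in an ADME assay on cells (Bos taurus) for cytotoxicity; a higher number here means that more compound is tolerated, a lower number that less compound is tolerated
- compound 2 `O=c1ccn([C@@H]2O[C@H](CO)C(OC3Sc4ccccc4S3)[C@@H]2OC2Sc3ccccc3S2)c(=O)[nH]1` gives 48000 nM in this assay

Only these two compounds have been measured so far, and compound 1 cannot be told apart from compound 2 on these numbers. Among the compounds with values here, the one measured step is a 1.4-fold lower number from compound 1 to compound 2 (0.15 log units; within the scatter) and it shows that adding that group left the number inside the normal spread of repeat measurements.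

Compound 3 `Nc1ccn([C@@H]2O[C@H](CO)C(O)[C@@H]2OC2Sc3ccccc3S2)c(=O)n1` keeps the rest of compound 1 and differs in one place: a group of 8 heavy atoms (4 carbon, 3 nitrogen, 1 oxygen; one six-membered aromatic ring with 2 hetero atoms) in place of a group of 8 heavy atoms (4 carbon, 2 nitrogen, 2 oxygen; one six-membered aromatic ring with 2 hetero atoms), on a saturated ring carbon on a saturated ring carbon of a five-membered non-aromatic ring with 1 oxygen.

The measured step lies elsewhere in the molecule, so it bears on this exchange only loosely. Within the data shown here, no measured pair shows this exchange itself, which leaves the range wide. With so little to go on, no shift beyond the scatter is expected in this assay and the expected step is a 1.1-fold lower number from compound 1 to compound 3 (0.05 log units; within the scatter) as a working guess. The estimated value of compound 3 is 60000 nM (25000 nM to 150000 nM).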

Compound 3, half-maximal cytotoxic concentration: 70400 nM
The estimate for compound 3 lay 1.2-fold (0.07 log units) below the measured number; the range from low to high includes it.
By their numbers in this assay, from the lowest: compounds 2, 1 and 3 (each within the scatter of the next).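

In this assay, replacing the group of 4 carbon, 2 nitrogen and 2 oxygen with one of 4 carbon, 3 nitrogen and 1 oxygen gives a 1.0-fold higher number from compound 1 to compound 3 (0.02 log units; within the scatter) for this change on the saturated ring carbon next to the ring oxygen. Within the data shown here, the earlier step concerned only a large group placed on an oxygen elsewhere in the molecule, so this is the first direct look at this position, and the exchange here also leaves the number within the normal spread of repeat measurements. No supporting measurement offers a reason for this outcome.

As far as these compounds go, both groups here are six-membered aromatic rings with 2 hetero atoms, so it remains open whether a ring bearing a methyl group or a fluorine atom, or a purine in their place, would also stay within the scatter. Among these compounds, it is also open whether the group of compound 3 would behave the same way when combined with the large group that compound 2 carries on its oxygen, since only a single change at a time can be read here.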